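Replacing the Hydroxymethylphenyl Group in a Glucagon Receptor Series

This account rests on a few compounds, and the source may have more. Where it says the series, first, only, none or still open, it means among the compounds named here.

Compound 1 `CCCCCc1c(C(C)C)nc(C(C)C)c(CO)c1-c1ccccc1CO` was examined in an assay on CHO cells for inhibition of Glucagon receptor (Homo sapiens), tested at 20 uM (on this read-out higher numbers stand for more inhibition at the one concentration tested (going by the name of the read-out) and lower numbers for less inhibition), where compound 1 gives 44%. Among the three compounds measured, compound 1 stands at the top of the numbers, yet its gap to compound 2 `CCC/C=C/c1c(C(C)C)nc(C(C)C)c(CO)c1-c1ccc(Cl)c(Cl)c1` falls within the scatter, compound 2 giving 39% in this assay. Compound 3 `CCCCCc1c(C(C)C)nc(C(C)C)c(C)c1-c1ccccc1O` sits clearly apart from compound 1, a gap outside the usual scatter; compound 3 gives 11% in this assay. No two of these three compounds differ in only one place, so no single step can be read from them.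

Compound 4 `CCCCCc1c(C(C)C)nc(C(C)C)c(CO)c1-c1cccc(C)c1` has not yet been measured. Compared with compound 1 it carries 3-methylphenyl in place of 2-(hydroxymethyl)phenyl on an aromatic carbon. Within the data shown here, the measured compounds hold no pair that isolates this change, so the expectation rests on the spread of their numbers alone. The step of a number 14 percentage points lower from compound 1 to compound 4 (beyond the scatter) is expected to be a modest drop, estimated to sit near the edge of the scatter. Compound 4 is expected to give about 30% in this assay, with an estimated range from 10% to 52%.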

Compound 4, a percentage reported as inhibition, at one concentration (the size of the read-out at that concentration, not a potency): 46%
For compound 4 the middle estimate is 16 percentage points below the measured one; the range from low to high includes it.
By their numbers in this assay, from the lowest: compound 3; then compounds 2, 1 and 4 (each within the scatter of the next).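

In this assay, among these compounds, putting 3-methylphenyl in place of 2-(hydroxymethyl)phenyl on the aromatic carbon opposite the ring nitrogen gives a number 2 percentage points higher from compound 1 to compound 4 (within the scatter), the first comparison in this set that isolates a single place. The read-out therefore does not separate these two groups at this position, although the entering group has 0 hydrogen-bond donors and 0 hydrogen-bond acceptors where the leaving group has 1 of each, and the hydroxymethyl group on this ring is not needed to keep the number of compound 1. No measurement shown explains why the two groups read alike.

As far as these compounds go, whether a phenyl ring carrying an aminomethyl or a carboxylic acid group in this place would read the same remains open. From the compounds shown here alone, with only one concentration tested, it also remains open whether compound 1 and compound 4 match in potency.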